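Benzothiazole in place of methylthiazole on the amide nitrogen

The compounds below may be only part of what the source reports. "The series", "measured", "known", "first", "only" and "open" are said of these compounds alone.

compound 1, `Cc1c(NC(=O)COc2ccc(/C=C3\SC(=O)NC3=O)cc2)c(=O)n(-c2ccccc2)n1C`: < 100000 nM
compound 2, `Cc1cnc(NC(=O)COc2ccc(/C=C3\SC(=O)NC3=O)cc2)s1`: < 100000 nM

In a functional assay on K562 cells (Homo sapiens) for cytotoxicity, read by sulforhodamine B assay, with a stated time of 48 h (a lower number here means a stronger inhibitor of growth, a higher number a weaker inhibitor of growth), compound 1 gives only a limit, < 100000 nM. In this assay compound 2 likewise gives only a limit, < 100000 nM. Within the data shown here, both values shown sit at that limit (the limit of < 100000 nM in this assay, at which 2 of the 2 values shown sit), so where compound 2 stands against the other measured compound cannot be read from the numbers, and no step between two measured compounds can be formed.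

Compound 3 `O=C(COc1ccc(/C=C2\SC(=O)NC2=O)cc1)Nc1nc2ccccc2s1` differs from compound 2 by 1,3-benzothiazol-2-yl in place of 5-methyl-1,3-thiazol-2-yl on an amide-type nitrogen. With both measured values being limits, neither a direction nor a size for this kind of change can be taken from the data, and the change is expected to shift the result by no more than the usual scatter. The step that the limit leaves unreadable from compound 2 to compound 3 is the expectation for this change. In this assay compound 3 is estimated at 30000 nM, with a range from 5000 nM to 100000 nM, and it may well again be reported only as a limit.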

Compound 3, concentration for total growth inhibition: < 100000 nM
Compound 3: a limit, no number; the forecaster's own chance of this, stated with the estimate: 60%; the middle value is on the limit's open side.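

Compound 3 gives < 100000 nM in this assay as a limit, not a number. Among these compounds, no step from compound 2 to compound 3 can be read, as every value shown now sits at the same limit: the limit of < 100000 nM in this assay, at which 3 of the 3 values shown sit. The compounds shown leave open how strongly each inhibits growth and whether 1,3-benzothiazol-2-yl in place of 5-methyl-1,3-thiazol-2-yl changes the result.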